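Fluorine on the benzyloxy ring of a coumarin amide

The source may report more compounds than this note shows. Statements on the series, on what has been measured and on what is new or still open speak of the compounds shown alone.

Measured compounds:
compound 1, `O=C(NC1CCCCC1)c1cc2ccc(OCc3ccccc3)cc2oc1=O`, with 64500 nM
compound 2, `COc1cc(NC(=O)c2cc3ccc(OCc4ccccc4)cc3oc2=O)cc(OC)c1`, with 3360 nM

Both compounds were tested in an in vitro assay on BTI-TN-5B1-4 cells for inhibition of Amine oxidase [flavin-containing] B (Homo sapiens), read by fluorescence; a lower number here means a stronger inhibitor, a higher number a weaker inhibitor. Going by the values given here, compound 2 stands at the lower of the two numbers: its nearest neighbour is compound 1, and the step of a 19-fold lower number from compound 1 to compound 2 (1.28 log units; beyond the scatter) is the only change measured so far, and it concerns the amide side of the shared core.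

Compound 3, `COc1cc(NC(=O)c2cc3ccc(OCc4ccc(F)cc4)cc3oc2=O)cc(OC)c1`, is not yet measured. It differs from compound 2 by fluoro in place of hydrogen on an aromatic carbon, which, cut one bond further out, reads as benzyloxy to (4-fluorobenzyl)oxy. Among the compounds with values here, no measured step touches this part of the molecule; the single measured step concerns the group on the amide-type nitrogen and therefore says nothing about what fluoro in this place does. With no bearing data, the reasonable expectation is a step of no size beyond the scatter, in either direction.

Compound 3 is therefore estimated at 3000 nM, with a range from 1000 nM to 9000 nM, meaning an expected step of a 1.1-fold lower number from compound 2 to compound 3 (0.05 log units; within the scatter).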

Compound 3, half-maximal inhibitory concentration: 21600 nM
The estimate for compound 3 lay 7.2-fold (0.86 log units) below the measured number, and the stated range ends below it.
By their numbers in this assay, from the lowest: compound 2; then compound 3; then compound 1.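

In this assay the benzyloxy end of the molecule proves not to be indifferent: with the 3,5-dimethoxyphenyl group on the amide-type nitrogen held fixed, the change to (4-fluorobenzyl)oxy gives a 6.4-fold higher number from compound 2 to compound 3 (0.81 log units; beyond the scatter) and so weakens inhibition by a step beyond the scatter. The earlier compounds had shown only that the group on the amide-type nitrogen matters, whereas this result shows that the number also answers to a change at the other end of the molecule, and that a single fluorine atom on an aromatic carbon, para to a large group, is enough to move it in the unfavourable direction. No available measurement bears on why this replacement of hydrogen costs potency.

The compounds shown leave open whether the loss is particular to fluoro or would also follow from chloro, methyl or a nitrile in the same place, and whether fluoro on another carbon of that ring would act alike. Going by these compounds alone, they also leave open whether the same change would weaken the cyclohexyl amide, as the fluoro step has been seen only with the 3,5-dimethoxyphenyl amide.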